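From Cyclopropyl to Thiophen-2-yl: Expecting Compound 4

The source may report more compounds than this note shows. Statements on the series, on what has been measured and on what is new or still open speak of the compounds shown alone.

Of the compounds shown here, three sharing one core have been measured in a functional assay on the whole organism (plasma, strain Sprague-Dawley) with Rattus norvegicus as the target, with a stated time of 2 h, at a dose of 50 mg/kg by the oral route; a lower number here means a weaker effect, a higher number a stronger effect of the compound at the dose given. Compound 1 `c1ccc(C(/N=C2\CCCCN2)C2CC2)cc1` gives 33% in this assay. Compound 2 `c1ccc(C(/N=C2\CCCCCN2)C2CC2)cc1` gives 41%, and compound 3 `Cc1ccc(C(/N=C2\CCCCCCCN2)C2CC2)c(C)c1` gives 47%. Compound 2 stands second highest of the three numbers, but the number for compound 3 lies within the scatter of it, as does the number for compound 1, so the three are not clearly separated from one another.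

Compound 4 `c1ccc(C(/N=C2\CCCCCN2)c2cccs2)cc1` has not yet been measured. It differs from compound 2 in one place: thiophen-2-yl in place of cyclopropyl on a saturated chain carbon bound to an aromatic carbon and a double-bonded nitrogen. Among the compounds with values here, no pair of measured compounds differs in this same way, so nothing measured shows how such a change moves the read-out in this assay. With no guide in the data, the estimated step is a number 1 percentage points lower from compound 2 to compound 4 (within the scatter), small, possible in either direction, and likely not beyond the scatter. Compound 4 is therefore expected to give about 40% in this assay, with a range from 20% to 60%.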

Compound 4, a percentage reported as inhibition, in the whole organism at one dose (the size of the read-out at that dose, not a potency): 46%
For compound 4 the middle estimate is 6 percentage points below the measured one; measured number inside the range.
By their numbers in this assay, from the lowest: compounds 1, 2, 4 and 3 (each within the scatter of the next, the first and the last beyond it).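

In this assay, within the data shown here, thiophen-2-yl in place of cyclopropyl on a saturated chain carbon bound to an aromatic carbon and a double-bonded nitrogen gives a number 5 percentage points higher from compound 2 to compound 4 (within the scatter), the first measured change at this place. A five-membered aromatic ring with one sulfur atom can therefore replace a three-membered carbon ring here, and the read-out at this one dose does not move clearly away from that of the smaller group. No measurement at hand accounts for this small step.

From the compounds shown here alone, whether the same exchange would behave alike on the core of compound 1 or on that of compound 3 remains open. So does whether phenyl, an amine or a longer chain at this place would bring a step beyond the scatter.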